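The source may hold more compounds than are shown below. What is called first, only, known or untested is meant among the compounds shown, and "the series" means these compounds.

Series notes. Compound 1 `COc1ccc(C2N=C(SCc3ccc(Cl)cc3)NC(C)=C2C(=O)Nc2ccc(F)cc2)cc1OC` and compound 2 `COc1ccc(C2N=C(SCc3ccc(F)cc3)NC(C)=C2C(=O)Nc2ccc(F)cc2)cc1OC` share one core and differ in a single place: fluoro in place of chloro on an aromatic carbon. In a functional assay on the whole organism (artery, strain albino) with Rattus norvegicus as the target, with a stated time of 300 min, at a dose of 10 mg/kg by the oral route (on this read-out higher numbers stand for more inhibition at the one dose given (going by the name of the read-out) and lower numbers for less inhibition), compound 1 gives 31.3% and compound 2 gives 37.9%, which is a number 6.6 percentage points higher from compound 1 to compound 2 (within the scatter). Compound 3 `CC1=C(C(=O)Nc2ccc(Br)cc2)C(c2ccc(Cl)cc2Cl)N=C(SCc2ccc(Cl)cc2)N1` is built on a different core; the difference between the two cores is not broken down here. In this assay compound 3 gives 38.5%, a number within the scatter of both compound 2 and compound 1, so no ordering among the three measured compounds is claimed.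

Compound 4 `CC1=C(C(=O)Nc2ccc(Br)cc2)C(c2ccc(Cl)cc2Cl)N=C(SCc2ccc(F)cc2)N1` is not yet measured. Among the measured compounds shown here, it differs from compound 3 by fluoro in place of chloro on an aromatic carbon, the same change, at the same place, as the one between compound 1 and compound 2. For the measured compounds named here, that earlier instance moved the read-out by a number 6.6 percentage points higher from compound 1 to compound 2 (within the scatter), within the scatter, and it is the only instance measured so far, on a core that differs from the one in compound 3. On that basis a step of about a number 2.5 percentage points higher from compound 3 to compound 4 (within the scatter) is expected for compound 4. Compound 4 is expected to give 41% in this assay, with a range from 29% to 53%.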

Compound 4, a percentage reported as inhibition, in the whole organism at one dose (the size of the read-out at that dose, not a potency): 38.5%
For compound 4 the middle estimate is 2.5 percentage points above the measured one, within the range that was stated.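

In this assay, fluoro in place of chloro on an aromatic carbon now has a second instance, with no change at the digits printed from compound 3 to compound 4 (within the scatter), and the two instances can be set side by side: the same change on two cores in this assay, a number 6.6 percentage points higher (within the scatter) from compound 1 to compound 2 and no change at the digits printed (within the scatter) from compound 3 to compound 4, 6.6 percentage points apart, within the scatter of two such steps. The change can thus be carried from the core of compound 1 to the core of compound 3 with no step beyond the scatter on either core, and the gap between the two steps gives no sign that the core alters the outcome. Among the compounds shown here, this does not show that the two cores respond identically or that the change is without effect, as only two pairs are available and a small real step on either core would stay hidden in the scatter.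

The compounds shown leave open how the read-out behaves with something other than a halogen at this place on the benzyl group, such as an amine or a carboxylic acid. Also open, on these data alone, is the effect of a longer chain in place of the 4-fluorobenzyl group on the sulfur.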